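Replacing 4-cyanophenyl with thiophen-2-yl in compound 4

A few compounds are considered here, and "the series" means these few. Any claim that something is new, unique, unknown or untested is made for them only; others in the source may bear on it.

Values in a functional assay on KB-VIN10 cells (Homo sapiens) for inhibition, with a stated time of 72 h; a lower number here means a stronger inhibitor, a higher number a weaker inhibitor:
- compound 1 `COc1ccc(S(=O)(=O)N2CCc3cccc(-c4ccc(F)c(F)c4)c32)cc1` gives 46 nM
- compound 2 `COc1ccc(S(=O)(=O)N2CCc3cccc(-c4ccc(F)cc4)c32)cc1` gives 94.6 nM
- compound 3 `COc1ccc(S(=O)(=O)N2CCc3cccc(-c4ccc(C#N)cc4)c32)cc1` gives 29.2 nM

Compound 3 cannot be separated from compound 1, with a 1.6-fold lower number from compound 1 to compound 3 (0.20 log units; within the scatter), but it clearly stands apart from compound 2, with a 3.2-fold lower number from compound 2 to compound 3 (0.51 log units; beyond the scatter). Compound 4 `COc1ccc(S(=O)(=O)N2CCc3cccc(-c4cccs4)c32)cc1` carries thiophen-2-yl in place of 4-cyanophenyl on an aromatic carbon. Among the measured compounds shown here, no measured step replaces the whole ring, so the evidence is indirect. The closest guides are a 3.2-fold lower number from compound 2 to compound 3 (0.51 log units; beyond the scatter) and a 2.1-fold higher number from compound 1 to compound 2 (0.31 log units; beyond the scatter), both modest. Compound 4 has no cyano group, so a modest rise is expected, and the estimated change is a 2.7-fold higher number from compound 3 to compound 4 (0.44 log units; beyond the scatter). Compound 4 is estimated at 80 nM, within an expected range of 30 nM to 220 nM.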

Compound 4, half-maximal inhibitory concentration: 251 nM
Beside the measured number, compound 4's estimate is 3.1-fold (0.50 log units) below it; measured number outside the range, above it.
By their numbers in this assay, from the lowest: compounds 3 and 1 (each within the scatter of the next); then compound 2; then compound 4.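

Thiophen-2-yl gives the largest rise seen at this position in this assay (an 8.6-fold higher number from compound 3 to compound 4 (0.93 log units; beyond the scatter)), and the loss also holds against the other two phenyl compounds (a 5.5-fold higher number from compound 1 to compound 4 (0.74 log units; beyond the scatter); a 2.7-fold higher number from compound 2 to compound 4 (0.42 log units; beyond the scatter)). Even compound 2, with the highest number among the phenyl compounds, stays ahead of compound 4, so a substituted phenyl ring is preferred here over this thiophene. No evidence shown accounts for the loss.

Because the ring and its substituent change together, the step cannot separate their contributions. An unsubstituted phenyl or a thiophene bearing a nitrile would be needed to tell them apart.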